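The compounds below may be only part of what the source reports. "The series", "measured", "known", "first", "only" and "open" are said of these compounds alone.

Measured in a functional assay on HOS-TE85 cells (Homo sapiens) for inhibition, read by CCK-8 assay, with a stated time of 72 h; on this read-out higher numbers stand for weaker inhibition and lower numbers for stronger inhibition:
- Compound 1 `O=C(NCCCCc1ccccc1)c1cccc(C2SCC(=O)N2c2cnccn2)c1`: > 1000 nM
- Compound 2 `COc1ccc(OC)c(N2C(=O)CSC2c2cccc(C(=O)NCCCCc3ccccc3)c2)c1`: > 1000 nM
- Compound 3 `COc1cc(F)ccc1N1C(=O)CSC1c1cccc(C(=O)NCCCCc2ccccc2)c1`: 71.1 nM

The entry for compound 1, > 1000 nM, is a limit of this assay and not a number. The entry for compound 2, > 1000 nM, is also a limit. Compound 3, at 71.1 nM, is therefore the only one of the three with a number.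

Compound 4 `O=C(NCCCCc1ccccc1)c1cccc(C2SCC(=O)N2c2ccccn2)c1` carries pyridin-2-yl in place of 4-fluoro-2-methoxyphenyl on an amide-type nitrogen in a ring.

The nearest measured change is an at least 14-fold lower number from compound 1 to compound 3 (1.14 log units; beyond the scatter), where 4-fluoro-2-methoxyphenyl replaces pyrazin-2-yl. The change an at least 14-fold lower number from compound 2 to compound 3 (1.14 log units; beyond the scatter) shows that a second substituted phenyl group also falls well short of compound 3. The step that the two limits leave unreadable from compound 1 to compound 2 cannot be read. Since compound 4 resembles compound 1 in carrying a nitrogen-containing ring at this place, a large loss is expected in this assay. The expected step is a 21-fold higher number from compound 3 to compound 4 (1.32 log units; beyond the scatter), toward weaker inhibition. For compound 4 the estimated value is 1500 nM, with an expected range of 300 nM to 6000 nM.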

Compound 4, half-maximal inhibitory concentration: 19.7 nM
Beside the measured number, compound 4's estimate is 76-fold (1.88 log units) above it, and the stated range ends above it.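

In this assay, pyridin-2-yl in place of 4-fluoro-2-methoxyphenyl gives a 3.6-fold lower number from compound 3 to compound 4 (0.56 log units; beyond the scatter), so on this amide-type nitrogen a six-membered aromatic ring with a hetero atom can exceed a substituted carbon-only ring. Pyridin-2-yl in place of pyrazin-2-yl gives an at least 50-fold lower number from compound 1 to compound 4 (1.70 log units; beyond the scatter), which shows that the presence of ring nitrogen alone does not settle the outcome at this place. Pyridin-2-yl in place of 2,5-dimethoxyphenyl gives an at least 50-fold lower number from compound 2 to compound 4 (1.70 log units; beyond the scatter), so this small unsubstituted ring also stands well apart from that substituted phenyl group.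

As far as these compounds go, the full size of the two large steps stays open, as each has only one end that is a number: the limit of > 1000 nM in this assay, at which 2 of the 4 values shown sit. Whether pyridin-3-yl, pyridin-4-yl or plain phenyl would hold this level also remains open.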